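Swapping the Cyanophenyl Group for a Cyclohexylmethyl Group

The compounds below may be only part of what the source reports. "The series", "measured", "known", "first", "only" and "open" are said of these compounds alone.

Compound 1 `COc1cccc(Cc2cnc(CCc3ccc(-c4ccccc4C(=O)O)cc3)[nH]2)c1` gives 79 nM in an in vitro functional assay on cells for agonist activity at Bombesin receptor subtype-3 (Mus musculus), read by luminescence and calcium flux; a lower number here means that less compound is needed, a higher number that more compound is needed for the effect.
Compound 2 `Cc1cccc(Cc2cnc(CCc3ccc(-c4ccccc4C(=O)O)cc3)[nH]2)c1` gives 75 nM in this assay.
Compound 3 `N#Cc1cccc(Cc2cnc(CCc3ccc(-c4ccccc4C(=O)O)cc3)[nH]2)c1` gives 20 nM in this assay.

All three share one core and differ only in the substituent on the aromatic ring attached through a single saturated carbon. Compound 3 stands lowest of the three numbers; the step of a 4.0-fold lower number from compound 1 to compound 3 (0.60 log units; beyond the scatter) and the step of a 3.8-fold lower number from compound 2 to compound 3 (0.57 log units; beyond the scatter) are both modest but beyond the scatter, while the step of a 1.1-fold lower number from compound 1 to compound 2 (0.02 log units; within the scatter) lies within it. Compound 4 `O=C(O)c1ccccc1-c1ccc(CCc2ncc(CCC3CCCCC3)[nH]2)cc1` introduces a different kind of change: cyclohexylmethyl in place of 3-cyanophenyl on a saturated chain carbon bound to an aromatic carbon. Going by the values given here, none of the measured steps removes the aromatic ring or the nitrile, so they bear on this only indirectly: they show that the nitrile is the one feature that set compound 3 apart. Losing it, together with the aromatic ring, is expected to give back at least that gain, so a modest rise in the number, a 7.5-fold higher number from compound 3 to compound 4 (0.88 log units; beyond the scatter), is expected for compound 4. Compound 4 is therefore estimated at 150 nM, with a range from 40 nM to 600 nM, which is wide since the change lies outside what the measured steps cover.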

Compound 4, half-maximal effective concentration: 33 nM
For compound 4 the middle estimate is 4.5-fold (0.66 log units) above the measured one; the whole stated range lies above it.
By their numbers in this assay, from the lowest: compounds 3 and 4 (each within the scatter of the next); then compounds 2 and 1 (each within the scatter of the next).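

In this assay, a low number at this position does not depend on keeping either the nitrile or the aromatic ring: cyclohexylmethyl in place of 3-cyanophenyl gives a 1.7-fold higher number from compound 3 to compound 4 (0.22 log units; within the scatter). Cyclohexylmethyl also separates from the two aromatic groups without a nitrile, with a 2.3-fold lower number from compound 2 to compound 4 (0.36 log units; beyond the scatter) and a 2.4-fold lower number from compound 1 to compound 4 (0.38 log units; beyond the scatter). The earlier compounds shown here varied only the substituent on an aromatic ring, where the nitrile alone stood apart, whereas compound 4 shows that a group with neither feature can stay within the scatter of compound 3.

No available evidence accounts for this match between two such different groups. On these data alone, it also remains open whether a longer chain in place of cyclohexylmethyl, or a cyclohexyl ring carrying an amine or a nitrile, would keep the number this low.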